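The source may report more compounds than this note shows. Statements on the series, on what has been measured and on what is new or still open speak of the compounds shown alone.

Working notes on the group carried on the amide-type nitrogen of the shared core, read in a functional assay on BaF3 cells (Mus musculus) for inhibition, read by MTT assay, with a stated time of 3 days; a higher number here means a weaker inhibitor of growth, a lower number a stronger inhibitor of growth. Within the data shown here, compound 1 `O=C(Nc1ccc(Nc2ncnc3c2OCCN3)cc1)Nc1ccc(C(F)(F)F)cc1` gives 10000 nM, the only true number so far. Compound 2 `Cc1cc(C)cc(NC(=O)Nc2ccc(Nc3ncnc4c3OCCN4)cc2)c1` reads > 10000 nM, which is a limit of the assay and not a number. Compound 3 `O=C(Nc1ccc(Nc2ncnc3c2OCCN3)cc1)Nc1cccs1` reads > 10000 nM, also a limit and not a number. Among the measured compounds shown here, the starting point is therefore no exact value for compound 3, and the series so far is summed up by the limit of > 10000 nM in this assay, at which 2 of the 3 values shown sit.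

Compound 4 `CC(C)(C)c1csc(NC(=O)Nc2ccc(Nc3ncnc4c3OCCN4)cc2)n1` brings this change: 4-(tert-butyl)-1,3-thiazol-2-yl in place of thiophen-2-yl on an amide-type nitrogen. In words, 4-(tert-butyl)-1,3-thiazol-2-yl stands in place of thiophen-2-yl on an amide-type nitrogen.

For the measured compounds named here, three measured steps touch this same place: a number no lower from compound 1 to compound 2 (the limit leaves the size open), a number no lower from compound 1 to compound 3 (the limit leaves the size open) and a step that the two limits leave unreadable from compound 2 to compound 3. None has a readable size, so they give no measure of how far a new group can move the number, and they point to no direction. Going by the values given here, the expectation rests mainly on compound 1 at 10000 nM, the one number available. In this assay the expected move is small, with a number no higher from compound 3 to compound 4 (the limit leaves the size open) estimated and no step beyond the scatter foreseen. For compound 4 the estimate is 10000 nM, with an expected range of 4000 nM to 20000 nM, and a report of only a limit is quite possible.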

Compound 4, concentration for 50% growth inhibition: > 10000 nM
Compound 4 was reported as a limit; the forecaster's own chance of this, stated with the estimate: 65%; the middle value sits exactly at the limit.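

In this assay compound 4 reads > 10000 nM, which is a limit and not a number. The new point is that enlarging the group on the amide-type nitrogen from thiophen-2-yl to 4-(tert-butyl)-1,3-thiazol-2-yl, with a second ring hetero atom and a tert-butyl group, still yields no exact value, so this position has now taken aryl and heteroaryl groups of differing size without any readable gain, and the series remains summed up by a single limit: the limit of > 10000 nM in this assay, at which 3 of the 4 values shown sit. Among these compounds, the one comparison with a direction is a number no lower from compound 1 to compound 4 (the limit leaves the size open), and neither it nor the other new steps can be read for size, so no ranking of these groups follows.

The compounds shown leave open whether any group at this position can bring the number clear of the limit, for instance a phenyl ring carrying an amine or a carboxylic acid, or a longer alkyl chain in place of the ring. They also leave open how far compound 2, compound 3 and compound 4 actually lie from one another, since only limits are available for them.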